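The source may report more compounds than this note shows. Statements on the series, on what has been measured and on what is new or still open speak of the compounds shown alone.

Values in an ADME assay on TZM cells (Homo sapiens) for cytotoxicity, read by CCK-8 assay, with a stated time of 2 days; a higher number here means that more compound is tolerated, a lower number that less compound is tolerated:

- compound 1 `CC(=O)Oc1ccc(/C=C/S(=O)(=O)CCc2ccc(NC(=O)c3ccccc3)cc2)cc1OC(C)=O`: 108000 nM
- compound 2 `CC(=O)Oc1ccc(/C=C/S(=O)(=O)CCc2ccc(NC(=O)c3cc(F)cc(F)c3)cc2)cc1OC(C)=O`: 225000 nM
- compound 3 `O=C(Nc1ccc(CCS(=O)(=O)/C=C/c2ccc(O)c(O)c2)cc1)c1ccc(F)cc1`: > 1000000 nM

Compound 3 has no number, only the limit > 1000000 nM. Compound 4 `Cc1ccc(C(=O)Nc2ccc(CCS(=O)(=O)/C=C/c3ccc(O)c(O)c3)cc2)cc1` differs from it by methyl in place of fluoro on an aromatic carbon, para to a large group. Within the data shown here, only one measured step bears on this, and only loosely: a 2.1-fold higher number from compound 1 to compound 2 (0.32 log units; beyond the scatter), with 3,5-difluorophenyl in place of phenyl on a carbonyl carbon. That step is modest and beyond the scatter. A similarly modest loss of fluoro-linked tolerance is expected in this assay, and a reading at the limit remains possible. The expected change is an at least 1.2-fold lower number from compound 3 to compound 4 (0.09 log units; that floor lies within the scatter). Compound 4 is estimated at 800000 nM, with an expected range of 250000 nM to 1000000 nM.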

Compound 4, half-maximal cytotoxic concentration: 168000 nM
Beside the measured number, compound 4's estimate is 4.8-fold (0.68 log units) above it; measured number below the stated range.
By their numbers in this assay, from the lowest: compounds 1, 4 and 2 (each within the scatter of the next, the first and the last beyond it). At a limit, above all of these: compound 3.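

In this assay the change from 4-fluorophenyl to 4-methylphenyl gives an at least 5.9-fold lower number from compound 3 to compound 4 (0.77 log units; beyond the scatter) and so shows that this single replacement, para to a large group, moves the number beyond the scatter. In both pairs shown, the member with fluoro gives the higher number, and neither pair goes against this. Compound 3 gives > 1000000 nM as a limit and not a number, so the size of the step is only a floor: the limit of > 1000000 nM in this assay, at which 1 of the 4 values shown sits.

From the compounds shown here alone, whether the fall follows the loss of fluoro or the entry of methyl remains open. Chloro, methoxy or an amine on the same aromatic carbon would help separate the two.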